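Notes on a dichlorophenyl replacement in a weak series

The source may report more compounds than this note shows. Statements on the series, on what has been measured and on what is new or still open speak of the compounds shown alone.

Compound 1 `COc1cc(-c2ncnn2-c2ccccc2)cc(OC)c1OC` carries a phenyl on an aromatic nitrogen of the shared core. In a functional assay on A549 cells (Homo sapiens) for antiproliferative activity, read by MTT assay, with a stated time of 72 h (on this read-out higher numbers stand for weaker inhibition and lower numbers for stronger inhibition), compound 1 reaches only the assay limit, > 10000 nM. Compound 2 `COc1cc(-n2ncnc2-c2ccc(F)cc2)cc(OC)c1OC` in this assay likewise gives only the limit, > 10000 nM. Both values sit at the same place, (the limit of > 10000 nM in this assay, at which 2 of the 2 values shown sit). Compound 3 `COc1cc(-c2ncnn2-c2ccc(Cl)c(Cl)c2)cc(OC)c1OC` differs from compound 1 by 3,4-dichlorophenyl in place of phenyl on an aromatic nitrogen. Going by the values given here, no step between measured compounds exists here, so any expectation rests on the change alone. For compound 3 a modest gain is expected, an at least 1.6-fold lower number from compound 1 to compound 3 (0.22 log units; that floor lies within the scatter), though it may still sit at the limit. Compound 3 is estimated at 6000 nM, between 1500 nM and 20000 nM.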

Compound 3, half-maximal inhibitory concentration: > 10000 nM
Compound 3: no number, only a limit; the forecaster's own chance of this, stated with the estimate: 55%; middle value at least 1.6-fold (0.22 log units) away from the limit.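

Going by these compounds alone, compound 3 gives only a limit, > 10000 nM, as compound 1 does, so no step from compound 1 to compound 3 can be read. Going by these compounds, whether 3,4-dichlorophenyl in place of phenyl shifts activity in this assay stays open.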